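The source may report more compounds than this note shows. Statements on the series, on what has been measured and on what is new or still open speak of the compounds shown alone.

Series notes, cytotoxicity. In a functional assay on A549 cells (Homo sapiens) for cytotoxicity, read by colorimetric assay and MTT assay, with a stated time of 3 days, tested at 1 uM (on this read-out lower numbers stand for a stronger effect and higher numbers for a weaker effect at the one concentration tested), compound 1 `COc1ccc(-c2nc(-c3ccccc3)c(-c3ccc4c(c3)NC(=O)CO4)[nH]2)cc1` gives 101%. Compound 2 `O=C1COc2ccc(-c3nn(-c4cc(Cl)cc(Cl)c4)cc3-c3ccccc3)cc2N1` gives 93.1% in this assay, and compound 3 `O=C1COc2ccc(-c3nn(-c4ccccc4)cc3-c3ccccc3)cc2N1` gives 92.2%; the three numbers lie within the usual scatter of one another, so compound 1 is not set apart from the others on this read-out. Among the measured compounds shown here, the one measured step, a number 0.9 percentage points lower from compound 2 to compound 3 (within the scatter), is the only change of an aryl substitution pattern in the set and bears loosely on the present change.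

Compound 4 `O=C1COc2ccc(-c3[nH]c(-c4ccc(Cl)cc4Cl)nc3-c3ccccc3)cc2N1` differs from compound 1 in one place: 2,4-dichlorophenyl in place of 4-methoxyphenyl on an aromatic carbon. On that precedent no step beyond the scatter is expected, in either direction, so the estimate for compound 4 is 97% (range 82% to 108%), a change of a number 4 percentage points lower from compound 1 to compound 4 (within the scatter).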

Compound 4, a percentage reported as activity, at one concentration (the size of the read-out at that concentration, not a potency): 97.4%
For compound 4 the middle estimate is 0.4 percentage points below the measured one; low and high end bracket the measured number.
By their numbers in this assay, from the lowest: compounds 3, 2, 4 and 1 (each within the scatter of the next).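

In this assay, among the compounds shown here, the exchange of 4-methoxyphenyl for 2,4-dichlorophenyl on the aromatic carbon between two ring nitrogen atoms gives a number 3.6 percentage points lower from compound 1 to compound 4 (within the scatter) and is the only direct reading at this position. Two differently substituted phenyl groups are therefore not told apart here at the one concentration tested. No data on hand account for this result.

Going by these compounds, whether an amine, a carboxylic acid or a longer chain at this position would give a number beyond the scatter stays open. With only these two groups compared here, the position's tolerance for other groups also stays undefined.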